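Chain extension on two cores, one shared change

The source may report more compounds than this note shows. Statements on the series, on what has been measured and on what is new or still open speak of the compounds shown alone.

Compound 1 `C=CCOc1ccc(C(=O)Nc2cccc(C)n2)cc1` and compound 2 `C=CCOc1ccc(C(=O)Nc2cccc(CC)n2)cc1` share a core and differ only at the chain on the ring bearing the amide nitrogen. In an in vitro assay on HEK-tsA201 cells for antagonist activity at Neuronal acetylcholine receptor; alpha3/beta4 (Homo sapiens), read by fluorescence and calcium flux (a lower number here means a stronger inhibitor, a higher number a weaker inhibitor), compound 1 gives 31700 nM, and compound 2 gives 27400 nM. The change between them is methyl in place of hydrogen on a saturated chain carbon bound to an aromatic carbon and the step it made is a 1.2-fold lower number from compound 1 to compound 2 (0.06 log units; within the scatter).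

Compound 3 `CCCNc1cccc(NC(=O)c2ccc(OCCC)cc2)n1` carries a different core; how the two cores differ is not broken down here. In this assay compound 3 gives 12600 nM, the lowest of the three numbers, and its gap to compound 2 and to compound 1 is beyond the scatter in both cases.

Compound 4 `CCCCNc1cccc(NC(=O)c2ccc(OCCC)cc2)n1` is not yet measured. Its difference from compound 3 is methyl in place of hydrogen on a saturated chain carbon, three bonds along the chain from a nitrogen on an aromatic ring. Against the earlier pair the place is not the same word for word: there the entering methyl sat on a saturated chain carbon bound to an aromatic carbon, here it sits on a saturated chain carbon three bonds along the chain from a nitrogen on an aromatic ring, so this is the same kind of change rather than the same change.

Among the measured compounds shown here, the expectation rests on a single measured example of this kind of change, compound 1 to compound 2, which gave a 1.2-fold lower number from compound 1 to compound 2 (0.06 log units; within the scatter); the step from compound 3 to compound 4 is estimated at a 1.2-fold lower number from compound 3 to compound 4 (0.08 log units; within the scatter), with a wide band because the place differs and only one prior step is known. Compound 4 is accordingly expected to give 10500 nM in this assay, between 5000 nM and 22000 nM.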

Compound 4, half-maximal inhibitory concentration: 77800 nM
Compound 4: the middle estimate sits 7.4-fold (0.87 log units) below what was measured; measured number above the stated range.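

In this assay, the propyl to butyl extension, methyl in place of hydrogen on a saturated chain carbon three bonds along the chain from a nitrogen on an aromatic ring, gave a 6.2-fold higher number from compound 3 to compound 4 (0.79 log units; beyond the scatter). The same kind of change therefore did not carry over from the core of compound 1 to the core of compound 3, where it had an effect that the earlier pair did not show: the same change on two cores in this assay, a 1.2-fold lower number (0.06 log units; within the scatter) from compound 1 to compound 2 and a 6.2-fold higher number (0.79 log units; beyond the scatter) from compound 3 to compound 4, 7.1-fold (0.85 log units) apart, beyond the scatter of two such steps This does not show that the core alone sets the outcome, since the entering methyl also sits in a different place on each core, and with a single step per core the two influences cannot be separated, nor can any general rule for chain extension in this series be drawn.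

Still open, as far as these compounds go, is how the number moves along the chain on the nitrogen of the core of compound 3, with an ethyl chain, a longer chain such as pentyl, or a branched chain such as isopropyl in that place. Also open, from the compounds shown here alone, is whether a terminal hydroxyl or an amine on that chain would behave as butyl does, and whether the propyl to butyl step would look the same with the allyl ether of compound 1 in place of the propyl ether.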